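Swapping a Nitrile for a Methoxy Group on the Sulfone

The source may hold more compounds than are shown below. What is called first, only, known or untested is meant among the compounds shown, and "the series" means these compounds.

Compound 1 `CC(O)(C(=O)Nc1cccc(S(=O)(=O)c2ccccc2)c1)C(F)(F)F`: > 30000 nM, a limit of the assay rather than a number
Compound 2 `CC(O)(C(=O)Nc1ccc(S(=O)(=O)c2ccccc2)c(F)c1)C(F)(F)F`: 1800 nM
Compound 3 `CC(O)(C(=O)Nc1ccc(S(=O)(=O)c2ccccc2C#N)cc1)C(F)(F)F`: 1100 nM

All three compounds carry the same amide-linked core, and they were tested in a functional assay (Cavia porcellus) with sulfonylurea receptors; K-ATP channels (Homo sapiens) as the target; on this read-out lower numbers stand for stronger inhibition and higher numbers for weaker inhibition. Compound 3 gives the lowest of the two numbers that were actually measured. Compound 2 sits close by, and its number lies within the scatter of compound 3, so no order between these two can be claimed. Compound 1 reaches only (the limit of > 30000 nM in this assay, at which 1 of the 3 values shown sits).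

Compound 4 `COc1ccc(S(=O)(=O)c2ccc(NC(=O)C(C)(O)C(F)(F)F)cc2)cc1` is the next compound, not yet measured. It differs from compound 3 in one place: 4-methoxyphenyl in place of 2-cyanophenyl on a sulfonyl sulfur. Going by the values given here, no pair among the measured compounds shows a swap of this kind, so there is no measured step to lean on. Both groups that trade places carry one hydrogen-bond acceptor and the same count of heavy atoms, and nothing measured here points to a shift in either direction. The step from compound 3 to compound 4 is therefore expected to stay within the scatter, as a 1.4-fold higher number from compound 3 to compound 4 (0.13 log units; within the scatter). For compound 4 in this assay a value of 1500 nM is expected, with a range from 500 nM to 5000 nM.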

Compound 4, half-maximal inhibitory concentration: > 30000 nM
Compound 4: only a limit was reported (the forecaster's own chance of this, stated with the estimate: 5%); middle value at least 20-fold (1.30 log units) from the limit.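

Trading 2-cyanophenyl for 4-methoxyphenyl on a sulfonyl sulfur gives an at least 27-fold higher number from compound 3 to compound 4 (1.43 log units; beyond the scatter), so the group at this place can matter a great deal, even though the two groups match in heavy-atom and hydrogen-bond-acceptor counts. In this assay compound 4 gives > 30000 nM, which is a limit of the assay and not a number. The earlier compounds offered no measured step of any kind, so this is the first direct sign among these compounds that a single change on the sulfone can separate a measurable value from the limit, which is now shared more widely: the limit of > 30000 nM in this assay, at which 2 of the 4 values shown sit.

This swap changes both the kind of group on the ring and its printed position, so the compounds shown cannot tell whether the loss follows from the nitrile leaving, the methoxy entering, or the change of position. A 2-methoxyphenyl group and a 4-cyanophenyl group on the same core would pull these apart, since each keeps one feature of the swap and changes the other.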